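This account rests on a few compounds, and the source may have more. Where it says the series, first, only, none or still open, it means among the compounds named here.

Measured compounds:
compound 1 `Cn1ccc2ccc(-c3cc(Nc4ccccc4S(N)(=O)=O)cc4nccnc34)cc21` — in an assay on lysate for inhibition of 6-phosphofructo-2-kinase/fructose-2,6-bisphosphatase 3 (Homo sapiens), with stated times of 0.5 min and 45 min (a lower number here means a stronger inhibitor, a higher number a weaker inhibitor), compound 1 gives 37600 nM
compound 2 `Cn1ccc2ccc(-c3cc(Nc4ccccc4S(=O)(=O)N4CCOCC4)cc4nccnc34)cc21` — in this assay compound 2 gives 2640 nM
compound 3 `CN(C)C(=O)c1ccncc1Nc1cc(-c2ccc3ccn(C)c3c2)c2nccnc2c1` — in this assay compound 3 gives > 100000 nM, which is a limit of the assay and not a number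

Compound 3 therefore stands at the limit of > 100000 nM in this assay, at which 1 of the 3 values shown sits; no number for it is known, only that it is weaker than the range the assay resolves. Compound 4 `CN1CCC(NC(=O)c2ccncc2Nc2cc(-c3ccc4ccn(C)c4c3)c3nccnc3c2)CC1=O` differs from compound 3 in one place: (1-methyl-2-oxopiperidin-4-yl)amino in place of dimethylamino on a carbonyl carbon. Within the data shown here, the only measured step, a 14-fold lower number from compound 1 to compound 2 (1.15 log units; beyond the scatter), concerns a substituent on a sulfonyl sulfur in another part of the shared core, and so it bears only loosely on the present change; both steps, however, replace a small amino-type group on an acyl-type atom with a ring-bearing group. Since compound 3 is a limit, the expected step in this assay is an at least 2.0-fold lower number from compound 3 to compound 4 (0.30 log units; that floor lies within the scatter), with no direction that can be called beyond the scatter. Compound 4 is estimated at 50000 nM in this assay, with a range from 8000 nM to 200000 nM.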

Compound 4, half-maximal inhibitory concentration: 48800 nM
Compound 4: the middle estimate sits 1.0-fold (0.01 log units) above what was measured; measured number inside the range.
By their numbers in this assay, from the lowest: compound 2; then compounds 1 and 4 (each within the scatter of the next). At a limit, above all of these: compound 3.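

In this assay, placing (1-methyl-2-oxopiperidin-4-yl)amino on this carbonyl carbon gives an at least 2.0-fold lower number from compound 3 to compound 4 (0.31 log units; beyond the scatter), so this amide position can yield a value the assay resolves, which dimethylamino did not. The direction matches that of the morpholin-4-yl change on the sulfonyl sulfur, though that change lies in another part of the shared core. The size of the new step remains a floor, and compound 3 is held only at a limit: the limit of > 100000 nM in this assay, at which 1 of the 4 values shown sits.

The change brings in a six-membered ring, a hydrogen-bond donor and a hydrogen-bond acceptor together, so the compounds shown do not separate their contributions. Open too, going by these compounds, is how a cyclohexylamino group, or a piperidin-4-ylamino group lacking both the ring carbonyl and the methyl, would read on this carbonyl carbon.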